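A few compounds are considered here, and "the series" means these few. Any claim that something is new, unique, unknown or untested is made for them only; others in the source may bear on it.

Measured so far:

compound 1, `CCCCCCCCO[C@@H]1O[C@@H](C)[C@H](OC(=O)CCCCC)[C@@H](O[C@@H]2O[C@@H](C)[C@H](OC(C)=O)[C@@H](O)[C@H]2OC(C)=O)[C@H]1O`, in a functional assay on KB cells (Homo sapiens) for cytotoxicity, in the presence of a further agent that is not named here (a lower number here means that less compound is needed, a higher number that more compound is needed for the effect), a limit, > 20 ug/mL

compound 2, `CCCCCCCCO[C@@H]1O[C@@H](C)[C@H](OC(=O)CCCCC)[C@@H](O[C@@H]2O[C@@H](C)[C@H](OC(C)=O)[C@@H](OC(C)=O)[C@H]2OC(C)=O)[C@H]1O`, in this assay 5.6 ug/mL

Going by the values given here, compound 2 stands as the only compound with a number in this assay; the value for compound 1 is a limit of the assay, not a number, and it sits at the limit of > 20 ug/mL in this assay, at which 1 of the 2 values shown sits. Compound 3, `CCCCCCCCO[C@@H]1O[C@@H](C)[C@H](OC(=O)CCCCC)[C@@H](O[C@@H]2O[C@@H](C)[C@H](O)[C@@H](OC(C)=O)[C@H]2OC(C)=O)[C@H]1O`, differs from compound 2 by hydrogen in place of acetyl on an oxygen on a saturated carbon. Among the compounds with values here, one measured step bears on this change: an at least 3.5-fold lower number from compound 1 to compound 2 (0.55 log units; beyond the scatter), which came from an acetyl group being added, though on a different oxygen of the same sugar than the one touched here. The step to compound 3 runs in the opposite direction, an acetyl leaving, so the expectation is that the number rises rather than falls, by a step of at least modest size, with a fair chance that compound 3 again reaches only the limit. Compound 3 is therefore expected to give about 15 ug/mL in this assay, within 5 ug/mL to 40 ug/mL, which would mean an expected step of a 2.7-fold higher number from compound 2 to compound 3 (0.43 log units; beyond the scatter).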

Compound 3, concentration for half-maximal effect: > 20 ug/mL
Compound 3 gave a limit, no number (the forecaster's own chance of this, stated with the estimate: 40%); middle value at least 1.3-fold (0.12 log units) away from the limit.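

In this assay, the acetoxy to hydroxy change on this oxygen on a saturated carbon brings an at least 3.5-fold higher number from compound 2 to compound 3 (0.55 log units; beyond the scatter), so this acetyl counts as well, and the earlier compounds had shown such a step only for another acetyl on the same sugar, with an at least 3.5-fold lower number from compound 1 to compound 2 (0.55 log units; beyond the scatter). Compound 3 gives > 20 ug/mL, which is a limit and not a number. Of the three compounds, only compound 2, which keeps both of these acetyl groups, gives a number, and losing either one ends at the same limit, so the two steps are known only as bounds and their sizes cannot be set against each other: the limit of > 20 ug/mL in this assay, at which 2 of the 3 values shown sit.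

The compounds shown leave open how far the true values of compound 1 and compound 3 lie from that limit, and so whether one of these two acetyl groups counts for more than the other. They also leave open whether another group on this oxygen, such as a benzoyl ester, a longer acyl chain or a methyl ether, would keep a measurable value in this assay.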